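Nitro in place of methoxy on the core of compound 1

The source may hold more compounds than are shown below. What is called first, only, known or untested is meant among the compounds shown, and "the series" means these compounds.

For the measured compounds named here, compound 1 `COc1cc(/C=C2\SC(=O)NC2=O)ccc1OCN1C(=O)c2ccccc2C1=O` gives 35100 nM in an assay on isolated protein for inhibition of Alpha glucosidase (Homo sapiens), read by spectrophotometry, with stated times of 15 min and 30 min (a lower number here means a stronger inhibitor, a higher number a weaker inhibitor), the only number in the set. Compound 2 `COc1cccc(/C=C2\SC(=O)NC2=O)c1OCN1C(=O)c2ccccc2C1=O` gives only a limit, > 100000 nM. Compound 3 `COc1cc(/C=C2\SC(=O)NC2=O)cc(OC)c1OCN1C(=O)c2ccccc2C1=O` likewise gives only a limit, > 100000 nM. Going by the values given here, the one measured step is an at least 2.8-fold higher number from compound 1 to compound 3 (0.45 log units; beyond the scatter), set against (the limit of > 100000 nM in this assay, at which 2 of the 3 values shown sit). Compound 4 `O=C1NC(=O)/C(=C/c2ccc(OCN3C(=O)c4ccccc4C3=O)c([N+](=O)[O-])c2)S1` differs from compound 1 by nitro in place of methoxy on an aromatic carbon. Among the compounds with values here, no measured step swaps one substituent for another; the sole step concerns adding methoxy, so it bears only loosely here. A change no larger than the scatter is expected, in either direction. Compound 4 is estimated at 40000 nM, with a range of 12000 nM to 140000 nM. The expected step is a 1.1-fold higher number from compound 1 to compound 4 (0.06 log units; within the scatter).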

Compound 4, half-maximal inhibitory concentration: 22500 nM
The estimate for compound 4 lay 1.8-fold (0.25 log units) above the measured number, and the stated range covers the measured number.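

On an aromatic carbon ortho to a large group, the only exchange of one substituent for another shown gives a 1.6-fold lower number from compound 1 to compound 4 (0.19 log units; within the scatter) in this assay. Methoxy is therefore not required at this position for a measurable number, and nitro reads the same within the scatter.

As far as these compounds go, whether an amine, a carboxylic acid or a longer chain at this position would also keep a measurable number remains open. Ranking across the series stays out of reach because much of it rests on a limit: the limit of > 100000 nM in this assay, at which 2 of the 4 values shown sit.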